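The compounds below may be only part of what the source reports. "The series", "measured", "known", "first", "only" and "open" are said of these compounds alone.

Compound 1 `CS(=O)(=O)Nc1ccc(Cl)c2c1CCCC2c1c[nH]cn1` gives 4.35 in a functional assay on Urethra for agonist activity at Alpha-1A adrenergic receptor (Oryctolagus cuniculus); on this read-out lower numbers stand for lower potency and higher numbers for higher potency (the scale is a negative logarithm). Compound 2 `O=S(=O)(Nc1cccc2c1CCCC2c1c[nH]cn1)C1CC1` gives 5.25 in this assay, the higher of the two numbers, with compound 1 standing beyond the scatter below it. Compound 3 `CCS(=O)(=O)Nc1cccc2c1CCCC2c1c[nH]cn1` has not yet been measured. It differs from compound 2 in one place: ethyl in place of cyclopropyl on a sulfonyl sulfur. Among the measured compounds shown here, no pair of measured compounds shows this change on its own, so the size of the step in this assay is unknown; a small shift, probably within the scatter, is expected. Compound 3 is estimated at 5.1, between 4.6 and 5.6. The expected step from this estimate is a number 0.15 log units lower from compound 2 to compound 3 (within the scatter).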

Compound 3, negative logarithm of the half-maximal effective concentration: 6.77
For compound 3 the middle estimate is 1.67 log units below the measured one; measured number above the stated range.
By their numbers in this assay, from the lowest: compound 1; then compound 2; then compound 3.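

On a sulfonyl sulfur whose other neighbour is the sulfonamide nitrogen, a small change of group has a large effect: in this assay, ethyl in place of cyclopropyl gives a number 1.52 log units higher from compound 2 to compound 3 (beyond the scatter). Among the compounds shown here, compound 1 differs from compound 2 in more than one place, so this is the first single change that can be read at this position. No measurement at hand bears on why the step is so large. On these data alone, whether a longer chain such as propyl on the sulfonyl sulfur would stand above or below ethyl remains open. As far as these compounds go, the separate contributions of the methyl and the chlorine of compound 1 also remain open.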